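Stretching the acyl chain by one carbon: compound 4

This account rests on a few compounds, and the source may have more. Where it says the series, first, only, none or still open, it means among the compounds named here.

Three close relatives sharing one core have been tested in an assay on isolated protein for inhibition of Nitric oxide synthase, inducible (Homo sapiens), with a stated time of 30 min, tested at 1 mM; on this read-out higher numbers stand for more inhibition at the one concentration tested (going by the name of the read-out) and lower numbers for less inhibition. Compound 1 `Nc1ccccc1C1=NN(C(=O)CCc2ccccc2)CC1` gives 5.64%, compound 2 `CC(=O)N1CCC(c2ccccc2N)=N1` gives 7.73%, and compound 3 `CCC(=O)N1CCC(c2ccccc2N)=N1` gives 6.88%. The three numbers sit close together: the step of a number 1.2 percentage points higher from compound 1 to compound 3 (within the scatter) and the step of a number 0.9 percentage points lower from compound 2 to compound 3 (within the scatter) are both within the usual scatter of this read-out, so compound 3 stands among the others without separating from either of them.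

Compound 4 `CCCC(=O)N1CCC(c2ccccc2N)=N1` differs from compound 3 in one place: methyl in place of hydrogen on a saturated chain carbon, two bonds along the chain from a carbonyl carbon. This acyl chain has already been varied twice among the measured compounds. Going from compound 2 to compound 3 added a methyl on a saturated chain carbon bound to a carbonyl carbon, and going from compound 1 to compound 3 removed a phenyl from the very carbon that now gains a methyl; neither move shifted the number beyond the scatter. Since both earlier changes on this chain left the read-out essentially where it was, a further methyl at the same place is expected to produce no step beyond the scatter, a number 0.1 percentage points higher from compound 3 to compound 4 (within the scatter). Compound 4 is therefore estimated at 7%, with a range from 0% to 17%.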

Compound 4, a percentage reported as inhibition, at one concentration (the size of the read-out at that concentration, not a potency): 0.35%
Compound 4: the middle estimate sits 6.7 percentage points above what was measured; low and high end bracket the measured number.
By their numbers in this assay, from the lowest: compounds 4, 1, 3 and 2 (each within the scatter of the next).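

In this assay, placing a methyl on the saturated chain carbon, two bonds along the chain from a carbonyl carbon, gives a number 6.5 percentage points lower from compound 3 to compound 4 (within the scatter) and marks the largest size of step yet seen from compound 3 on this chain. The matching comparisons give a number 7.4 percentage points lower from compound 2 to compound 4 (within the scatter) and a number 5.3 percentage points lower from compound 1 to compound 4 (within the scatter) and so, although these steps are larger than the earlier ones, none of them separates compound 4 from its relatives, and hydrogen, methyl and phenyl at this carbon remain indistinguishable on this read-out. No supporting measurement is available to explain the size of these steps.

Going by these compounds, what stays open is whether anything at this position can move the number clear of the scatter, for example a longer chain such as butyl, or an amine or a carboxylic acid at the end of the chain. A repeat measurement of these compounds, or a test at more than one concentration, would also be needed to show whether the size of the step from the propanoyl to the propylcarbonyl chain is real.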